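This account rests on a few compounds, and the source may have more. Where it says the series, first, only, none or still open, it means among the compounds named here.

In an ADME assay on RAW264.7 cells (Mus musculus) for cytotoxicity, read by MTT assay, with a stated time of 24 h, in the absence of a further agent (on this read-out lower numbers stand for stronger inhibition and higher numbers for weaker inhibition), compound 1 (`COCCCCOc1ccc(C(O)C2OC(=O)c3c(OC)cc(OC)cc32)cc1`) gives > 40000 nM as a limit, not a number. Compound 2 (`C=CCCOc1ccc(C(O)C2OC(=O)c3c(OC)cc(OC)cc32)cc1`) gives > 40000 nM as a limit as well. Compound 3 (`COc1cc(OC)c2c(c1)C(C(O)c1ccc(OCc3ccc(F)cc3)cc1)OC2=O`) gives > 40000 nM as a limit too, so it has no number of its own and stands with the other two (the limit of > 40000 nM in this assay, at which 3 of the 3 values shown sit).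

Compound 4 (`COc1cc(OC)c2c(c1)C(C(O)c1ccc(OCc3ccc(Br)cc3)cc1)OC2=O`) carries bromo in place of the fluoro of compound 3, on an aromatic carbon, para to a large group (bromo in place of fluoro on an aromatic carbon). The measured steps all exchange other groups, and none of them has a readable size: the set holds a step that the two limits leave unreadable from compound 1 to compound 2 and a step that the two limits leave unreadable from compound 1 to compound 3 and also a step that the two limits leave unreadable from compound 2 to compound 3 with nothing more to carry over. The expectation therefore rests on compound 3, whose > 40000 nM is a limit.

The expected change is a step that the limit leaves unreadable from compound 3 to compound 4 in this assay with no direction to call. Compound 4 is estimated at 45000 nM (range 20000 nM to 80000 nM), and the assay is expected to report only a limit again.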

Compound 4, half-maximal inhibitory concentration: > 40000 nM
Compound 4 was reported as a limit (the forecaster's own chance of this, stated with the estimate: 80%); the middle value does not contradict the limit.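

Compound 4, like compound 1, compound 2 and compound 3, is reported only as a limit, so no step to compound 4 can be read: the limit of > 40000 nM in this assay, at which 4 of the 4 values shown sit.

The compounds shown leave open whether any of these group exchanges changes the result in this assay.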